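Chlorophenyl positional change in a low-inhibition series

This account rests on a few compounds, and the source may have more. Where it says the series, first, only, none or still open, it means among the compounds named here.

Measured so far:
compound 1 `CC(C)(C)Cc1csc(N)c1C(=O)c1cccc(Cl)c1`: 2%
compound 2 `CC(C)(C)Cc1c(Br)sc(N)c1C(=O)c1ccc(Cl)cc1`: 1%

In an assay on CHO cells for displacement of a labelled ligand from adenosine receptor A1 (Homo sapiens), read by scintillation counting, tested at 10 uM (on this read-out lower numbers stand for less inhibition and higher numbers for more inhibition at the one concentration tested (going by the name of the read-out)), compound 1 gives 2%, and in this assay compound 2 gives 1%. The two numbers lie within the scatter of each other, so neither compound can be set apart from the other; both sit at the low end of the read-out, where the displacement of the labelled ligand is small. For the measured compounds named here, compound 1 and compound 2 differ in more than one place, so no single step between them can be read from these two values.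

Compound 3 `CC(C)(C)Cc1c(Br)sc(N)c1C(=O)c1cccc(Cl)c1` is not yet measured. It differs from compound 2 in one place: 3-chlorophenyl in place of 4-chlorophenyl on a carbonyl carbon. The same two chlorophenyl groups appear in compound 1 and compound 2 , and both of those give low numbers, so no step beyond the scatter is expected in this assay. For compound 3 the expected value is 2%, with a range from -6% to 12%, which means a step of a number 1 percentage points higher from compound 2 to compound 3 (within the scatter) that is expected to stay inside the scatter.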

Compound 3, a percentage reported as inhibition, at one concentration (the size of the read-out at that concentration, not a potency): 1%
Estimate against measurement, compound 3: 1 percentage points above; the range from low to high includes it.
By their numbers in this assay, from the lowest: compounds 2, 3 and 1 (each within the scatter of the next).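

In this assay, for the compounds shown here, 3-chlorophenyl in place of 4-chlorophenyl on a carbonyl carbon gives no change at the digits printed from compound 2 to compound 3 (within the scatter), the first reading of this change on its own. Bromo in place of hydrogen on an aromatic carbon, with 3-chlorophenyl held fixed, gives a number 1 percentage points lower from compound 1 to compound 3 (within the scatter), so neither single change separates these compounds at the low end of the read-out. Nothing available bears on why these numbers stay low.

Going by these compounds, whether any group other than chlorophenyl on this carbonyl carbon, such as a cyclohexyl or a phenyl carrying a carboxylic acid, would move the number remains open. Also open, on these data alone, is whether a shorter chain in place of the 2,2-dimethylpropyl group of the shared core would do so.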